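Adding a methylpyrrolidine to the amide nitrogen of compound 3

A few compounds are considered here, and "the series" means these few. Any claim that something is new, unique, unknown or untested is made for them only; others in the source may bear on it.

Compound 3 `CNC(=O)c1ccncc1Nc1cc(-c2ccc3ccn(C)c3c2)c2nccnc2c1` gives 7020 nM in an assay on lysate for inhibition of 6-phosphofructo-2-kinase/fructose-2,6-bisphosphatase 3 (Homo sapiens), with stated times of 0.5 min and 45 min (a higher number here means a weaker inhibitor, a lower number a stronger inhibitor), the highest of the two numbers at hand, while compound 1 `CN1CCC(NS(=O)(=O)c2ccccc2Nc2cc(-c3ccc4ccn(C)c4c3)c3nccnc3c2)C1` gives 3160 nM in this assay. Compound 2 `Cn1ccc2ccc(-c3cc(Nc4ccccc4S(=O)(=O)NCC4CCOCC4)cc4nccnc34)cc21` reaches only a limit of the assay, > 100000 nM in this assay. Among the compounds with values here, the single measured step, an at least 31-fold higher number from compound 1 to compound 2 (1.50 log units; beyond the scatter), is large, and it shows that losing the 1-methylpyrrolidin-3-yl group went with a much weaker compound. Compound 4 `CN1CCC(N(C)C(=O)c2ccncc2Nc2cc(-c3ccc4ccn(C)c4c3)c3nccnc3c2)C1` differs from compound 3 by 1-methylpyrrolidin-3-yl in place of hydrogen on an amide-type nitrogen. That measured step concerns a sulfonamide nitrogen rather than an amide-type one, so it bears on this change only loosely, and compound 3 already lacks the group that compound 1 carries. Compound 4 is therefore expected to give a somewhat lower number, a 2.8-fold lower number from compound 3 to compound 4 (0.45 log units; beyond the scatter), with an estimated 2500 nM in this assay, spanning 600 nM to 10000 nM.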

Compound 4, half-maximal inhibitory concentration: 39700 nM
Estimate against measurement, compound 4: 16-fold (1.20 log units) below; measured number outside the range, above it.
By their numbers in this assay, from the lowest: compound 1; then compound 3; then compound 4. At a limit, above all of these: compound 2.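

Putting 1-methylpyrrolidin-3-yl in place of hydrogen on the amide-type nitrogen gives a 5.7-fold higher number from compound 3 to compound 4 (0.75 log units; beyond the scatter) in this assay, so at this position the group goes with a weaker compound. The earlier step ran the other way: on a sulfonamide nitrogen, compound 1 with this group stood at the lower number, so that direction does not carry over to the amide-type nitrogen.

Going by these compounds, whether a small group such as ethyl, or an open-chain amine such as 2-(dimethylamino)ethyl, would go the same way on this nitrogen stays open. Nothing shown here bears on why this step goes as it does.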